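Swapping a branched chain for a benzyl group on the indole nitrogen

The source may hold more compounds than are shown below. What is called first, only, known or untested is meant among the compounds shown, and "the series" means these compounds.

Compound 3 `CCCCC(CC)n1ccc2cc(/C(C)=C/C(=O)Nc3ccccc3OCCCC(=O)O)ccc21` sits second highest among the three measured compounds in an assay on Prostate gland for inhibition of steroid 5-alpha-reductase (Rattus norvegicus) (on this read-out higher numbers stand for weaker inhibition and lower numbers for stronger inhibition), giving 7.1 nM. Its nearest neighbour is compound 2 `CCCCC(C)n1ccc2cc(/C(C)=C/C(=O)Nc3ccccc3OCCCC(=O)O)ccc21`, which gives 6 nM, and the step of a 1.2-fold higher number from compound 2 to compound 3 (0.07 log units; within the scatter) is within the scatter. Furthest away is compound 1 `CCCCCCn1ccc2cc(/C(C)=C/C(=O)Nc3ccccc3OCCCC(=O)O)ccc21`, which gives 77 nM; here the chain on the aromatic nitrogen is unbranched, and the steps of a 13-fold lower number from compound 1 to compound 2 (1.11 log units; beyond the scatter) and an 11-fold lower number from compound 1 to compound 3 (1.04 log units; beyond the scatter) show that branching at the carbon attached to that nitrogen goes with much stronger inhibition.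

Compound 4 `C/C(=C\C(=O)Nc1ccccc1OCCCC(=O)O)c1ccc2c(ccn2Cc2ccc(C)cc2)c1` differs from compound 3 by 4-methylbenzyl in place of 1-ethylpentyl on an aromatic nitrogen. Within the data shown here, the new group, like the hexyl of compound 1, has no branch at the carbon attached to the nitrogen, but it carries an aromatic ring, for which none of the measured compounds gives guidance. Among the measured compounds shown here, the only steps that bear on the change are the branching steps from compound 1, and they suggest that losing the branch tends towards weaker inhibition. The expected step is therefore a 5.6-fold higher number from compound 3 to compound 4 (0.75 log units; beyond the scatter), towards a higher number, with wide uncertainty. Compound 4 is estimated to give 40 nM in this assay, within a range from 8 nM to 200 nM.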

Compound 4, half-maximal inhibitory concentration: 88 nM
Compound 4: the middle estimate sits 2.2-fold (0.34 log units) below what was measured, within the range that was stated.
By their numbers in this assay, from the lowest: compounds 2 and 3 (each within the scatter of the next); then compounds 1 and 4 (each within the scatter of the next).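

In this assay, the 4-methylbenzyl group does not keep the strong inhibition seen with the branched chains, as shown by the large steps of a 12-fold higher number from compound 3 to compound 4 (1.09 log units; beyond the scatter) and a 15-fold higher number from compound 2 to compound 4 (1.17 log units; beyond the scatter). Against the unbranched hexyl chain, the step of a 1.1-fold higher number from compound 1 to compound 4 (0.06 log units; within the scatter) is within the scatter, so the aromatic ring brings no readable change, and among these four compounds the two with a branch at the carbon attached to the nitrogen, compound 2 and compound 3, give the lower numbers, with neither compound 1 nor compound 4 going against this. Nothing measured here explains this difference between the groups.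

Since compound 4 changes both the branching and the ring compared with compound 3, a 1-phenylethyl group, which has an aromatic ring and a branch at that same carbon, would test whether branching still goes with stronger inhibition when the ring is present. The compounds shown also leave open what the ring's methyl contributes, which plain benzyl could address, and whether a saturated ring, as in cyclohexylmethyl, would behave like the 4-methylbenzyl group.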